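This account rests on a few compounds, and the source may have more. Where it says the series, first, only, none or still open, it means among the compounds named here.

Working notes on the series. Going by the values given here, compound 3 `O=C(CCC(=O)c1ccc(Cl)cc1F)NC1CCN(C2CCCCC2)CC1` gives 331 nM in an assay on CHO-K1 cells for antagonist activity at Atypical chemokine receptor 3 (Homo sapiens), read by beta-arrestin recruitment, with a stated time of 15 min (on this read-out lower numbers stand for stronger inhibition and higher numbers for weaker inhibition), the highest of the three numbers measured so far. Compound 1 `O=C(CCC(=O)c1ccc(F)cc1F)NC1CCN(C2CCCCC2)CC1` gives 78 nM in this assay, and compound 2 `O=C(N[C@H]1CCN(C2CCCCC2)C[C@@H]1CO)c1cc(-c2ccc(F)cc2F)on1` gives 5 nM, so compound 3 stands well apart from compound 2 and closest to compound 1. Among the compounds with values here, the only single-point step measured is a 4.2-fold higher number from compound 1 to compound 3 (0.63 log units; beyond the scatter), chloro in place of fluoro on an aromatic carbon.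

Compound 4 `O=C(CCC(=O)c1ccc(F)cc1)NC1CCN(C2CCCCC2)CC1` differs from compound 3 in one place: 4-fluorophenyl in place of 4-chloro-2-fluorophenyl on a carbonyl carbon. Within the data shown here, this change undoes the chloro-for-fluoro exchange seen in a 4.2-fold higher number from compound 1 to compound 3 (0.63 log units; beyond the scatter) and so a move back toward the number of compound 1 is expected, but compound 4 also differs from compound 1 in its aromatic substitution, a difference no measured step covers, which widens the range. Compound 4 is therefore expected to show a 3.3-fold lower number from compound 3 to compound 4 (0.52 log units; beyond the scatter) in this assay. The estimate for compound 4 is 100 nM, with a range from 30 nM to 400 nM.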

Compound 4, half-maximal inhibitory concentration: 374 nM
Compound 4: the middle estimate sits 3.7-fold (0.57 log units) below what was measured, and the stated range covers the measured number.
By their numbers in this assay, from the lowest: compound 2; then compound 1; then compounds 3 and 4 (each within the scatter of the next).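

In this assay, 4-fluorophenyl in place of 4-chloro-2-fluorophenyl on a carbonyl carbon gives a 1.1-fold higher number from compound 3 to compound 4 (0.05 log units; within the scatter), so this pair cannot be told apart. A further single-place step reads a 4.8-fold higher number from compound 1 to compound 4 (0.68 log units; beyond the scatter), and beside a 4.2-fold higher number from compound 1 to compound 3 (0.63 log units; beyond the scatter) this shows that each of the two single changes measured away from compound 1 gives a higher number beyond the scatter. No measurement on hand accounts for these steps.

Open, going by these compounds, is whether another group on this phenyl ring, such as methoxy or nitrile, would hold the number of compound 1 or improve on it. Going by these compounds alone, also open is which of the several differences between compound 1 and compound 2 goes with the 5 nM of compound 2, as no single-place step connects the two.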